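Methyl for methoxy on the thiourea aryl of compound 1

A few compounds are considered here, and "the series" means these few. Any claim that something is new, unique, unknown or untested is made for them only; others in the source may bear on it.

Three compounds of the shared core are measured. Compound 1 `COc1ccc(NC(=S)NC(=O)c2cn(-c3ccccc3)nc2-c2ccc(OC)cc2)cc1` gives 4210 nM in a functional assay on MCF7 cells (Homo sapiens) for inhibition, read by CCK-8 assay, with a stated time of 48 h; on this read-out lower numbers stand for stronger inhibition and higher numbers for weaker inhibition. Among the measured compounds shown here, compound 2 `O=C(NC(=S)Nc1ccc(Cl)cc1)c1cn(-c2ccccc2)nc1-c1ccc(Cl)cc1` gives 5360 nM and compound 3 `O=C(NC(=S)Nc1ccc(Cl)cc1)c1cn(-c2ccccc2)nc1-c1ccc(F)cc1` gives 5470 nM; the one single-point step among them, a 1.0-fold higher number from compound 2 to compound 3 (0.01 log units; within the scatter), stays within the scatter. Compound 1 stands at the lower end of these three numbers, yet its gaps to compound 2 and to compound 3 are both within the scatter, so the three cannot be separated.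

Compound 4 `COc1ccc(-c2nn(-c3ccccc3)cc2C(=O)NC(=S)Nc2ccc(C)cc2)cc1` differs from compound 1 by methyl in place of methoxy on an aromatic carbon. For the measured compounds named here, no measured step touches this position: the only step in hand, fluoro for chloro, sits on a different ring and was itself flat. Nothing in the series therefore argues for a move in this assay beyond the scatter in either direction.

Compound 4 is accordingly expected to land near compound 1, at an estimated 4500 nM with a range of 2000 nM to 10000 nM, which means an expected step of a 1.1-fold higher number from compound 1 to compound 4 (0.03 log units; within the scatter).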

Compound 4, half-maximal inhibitory concentration: 4630 nM
Beside the measured number, compound 4's estimate is 1.0-fold (0.01 log units) below it; the measured number falls inside the stated range.
By their numbers in this assay, from the lowest: compounds 1, 4, 2 and 3 (each within the scatter of the next).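

Among the compounds shown here, replacing methoxy with methyl in going from (4-methoxyphenyl)amino to (4-methylphenyl)amino gives the first reading at this position in this assay: a 1.1-fold higher number from compound 1 to compound 4 (0.04 log units; within the scatter). The earlier compounds shown here offered only a fluoro-for-chloro step on another ring, whereas this step shows that removing the methoxy oxygen and its counted hydrogen-bond acceptor leaves the two compounds inseparable on this read-out. No evidence on why this step stays so small is available.

As far as these compounds go, one swap between two small groups cannot show how far this position tolerates change, so the effect of an amine, a carboxylic acid or a longer chain such as butoxy here remains open. Also open, from the compounds shown here alone, is whether chloro on this ring, taken alone against methyl or methoxy, would give the same result.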